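This account rests on a few compounds, and the source may have more. Where it says the series, first, only, none or still open, it means among the compounds named here.

In a functional assay on HL-60 cells (Homo sapiens) for antiproliferative activity, with a stated time of 72 h (a lower number here means a stronger inhibitor, a higher number a weaker inhibitor), compound 1 `CC(C)(CO)Cn1nc(-c2c[nH]c3ccccc23)c2c(N)ncnc21` gives 27600 nM and compound 2 `Nc1ncnc2c1c(-c1c[nH]c3ccccc13)nn2CC1CCNCC1` gives 17900 nM, so the two stand level. Among the compounds with values here, the only measured step, a 1.5-fold lower number from compound 1 to compound 2 (0.19 log units; within the scatter), concerns a different group and offers indirect guidance at best. Compound 3 `CC(C)(C)n1nc(-c2c[nH]c3ccccc23)c2c(N)ncnc21` has tert-butyl in place of 2-(hydroxymethyl)-2-methylpropyl on an aromatic nitrogen. Within the data shown here, no measured step covers this exact change, so a shift beyond the scatter in this assay is not expected, and either direction remains open. The estimated value for compound 3 is 22000 nM, within an expected range of 8000 nM to 55000 nM. The expected step is a 1.3-fold lower number from compound 1 to compound 3 (0.10 log units; within the scatter).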

Compound 3, half-maximal inhibitory concentration: 7800 nM
Estimate against measurement, compound 3: 2.8-fold (0.45 log units) above; measured number below the stated range.
By their numbers in this assay, from the lowest: compound 3; then compounds 2 and 1 (each within the scatter of the next).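

In this assay, the group on the aromatic nitrogen does move the read-out: tert-butyl in place of 2-(hydroxymethyl)-2-methylpropyl gives a 3.5-fold lower number from compound 1 to compound 3 (0.55 log units; beyond the scatter). Tert-butyl in place of (piperidin-4-yl)methyl gives a 2.3-fold lower number from compound 2 to compound 3 (0.36 log units; beyond the scatter), so compound 3 separates from both, whereas compound 1 and compound 2 showed no such separation. Nothing available explains these steps.

Compound 3 differs from compound 1 in both the heavy-atom count and the hydroxyl, and the two cannot be told apart here. A plain 2-methylpropyl chain without the hydroxyl, or an isopropyl group, on the same nitrogen would be the open comparison.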